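The source may hold more compounds than are shown below. What is called first, only, known or untested is meant among the compounds shown, and "the series" means these compounds.

Compound 1 `Cc1c(F)cccc1CCCCOc1ccc(/C=C/c2cccc3c(CCCC(=O)O)cn(CC(=O)O)c23)cc1`: in a physicochemical assay for permeability, using PAMPA, with a stated time of 4 h, at pH 6.2, tested at 50 uM (a lower number here means that the compound crosses the layer more slowly, a higher number that the compound crosses the layer faster), compound 1 gives 3.5 10^-6 cm/s.
Compound 2 `O=C(O)CCCc1cn(CC(=O)O)c2c(/C=C/c3ccc(OCCCCOc4ccccc4)cc3)cccc12`: in this assay compound 2 gives 1.6 10^-6 cm/s.
Compound 3 `Cc1c(CCCC(=O)O)c2cccc(/C=C/c3ccc(OCCCCc4c(F)ccc(F)c4F)cc3)c2n1CC(=O)O`: in this assay compound 3 gives 4.4 10^-6 cm/s.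

Compound 3 has the highest number of the three; compound 1 lies within the scatter of it, while compound 2 lies beyond it. Among the measured compounds shown here, the only measured step, a 2.2-fold lower number from compound 1 to compound 2 (0.34 log units; beyond the scatter), alters the far end of the chain, not the ring carbon where compound 4 `O=C(O)CCCc1cn(CC(=O)O)c2c(/C=C/c3ccc(OCCCCc4c(F)ccc(F)c4F)cc3)cccc12` differs from compound 3: hydrogen in place of methyl on an aromatic carbon. For the measured compounds named here, no measured step bears on this change, so the expectation rests on compound 3 alone. The change is expected to give no step beyond the scatter, a 1.3-fold lower number from compound 3 to compound 4 (0.10 log units; within the scatter). Compound 4 is therefore expected to give about 3.5 10^-6 cm/s in this assay, within the range 1.8 10^-6 cm/s to 7 10^-6 cm/s.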

Compound 4, apparent permeability: 1.4 10^-6 cm/s
For compound 4 the middle estimate is 2.5-fold (0.40 log units) above the measured one, and the stated range ends above it.
By their numbers in this assay, from the lowest: compounds 4 and 2 (each within the scatter of the next); then compounds 1 and 3 (each within the scatter of the next).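

In this assay, this carbon of the five-membered aromatic ring, next to the ring nitrogen, proves sensitive: hydrogen in place of methyl gives a step beyond the scatter (a 3.1-fold lower number from compound 3 to compound 4 (0.50 log units; beyond the scatter)). Among compounds without this methyl, the phenoxy end of the chain and the 2,3,6-trifluorophenyl end stay within the scatter (a 1.1-fold lower number from compound 2 to compound 4 (0.06 log units; within the scatter)), whereas the 3-fluoro-2-methylphenyl end does not (a 2.5-fold lower number from compound 1 to compound 4 (0.40 log units; beyond the scatter)). Nothing measured here explains the loss on removing the methyl. On these data alone, whether the methyl has the same effect with other chain ends remains open. So does what an ethyl group or a chlorine atom on this carbon would give.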